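The source may report more compounds than this note shows. Statements on the series, on what has been measured and on what is new or still open speak of the compounds shown alone.

Working notes on the series.

Three analogues share one core and differ only in the group on the nitrogen on the aromatic ring. Compound 1 `COc1cc2ncnc(Nc3cccc(Br)c3)c2cc1OCCCCC(=O)Nc1ccc(S(N)(=O)=O)cc1` carries a bromo group and in a functional assay on A-431 cells (Homo sapiens) for antiproliferative activity, read by MTT assay, with a stated time of 72 h (a higher number here means a weaker inhibitor, a lower number a stronger inhibitor), compound 1 gives 9750 nM. Compound 2 `COc1cc2ncnc(Nc3cccc(F)c3)c2cc1OCCCCC(=O)Nc1ccc(S(N)(=O)=O)cc1` carries a fluoro group instead, and in this assay compound 2 gives 29900 nM, the highest of the three numbers; the step of a 3.1-fold higher number from compound 1 to compound 2 (0.49 log units; beyond the scatter) lies beyond the scatter. Compound 3 `COc1cc2ncnc(Nc3cccc(C)c3)c2cc1OCCCCC(=O)Nc1ccc(S(N)(=O)=O)cc1` carries a methyl group, and in this assay compound 3 gives 7460 nM; the step of a 4.0-fold lower number from compound 2 to compound 3 (0.60 log units; beyond the scatter) is beyond the scatter, whereas a 1.3-fold lower number from compound 1 to compound 3 (0.12 log units; within the scatter) is within it.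

Compound 4 `COc1cc2ncnc(Nc3cc(F)c(F)c(F)c3)c2cc1OCCCCC(=O)Nc1ccc(S(N)(=O)=O)cc1` is not yet measured. The change from compound 2 is 3,4,5-trifluorophenyl in place of 3-fluorophenyl on a nitrogen on an aromatic ring. Neither measured step bears directly on adding two further fluoro groups to the same ring; the two steps only show that the fluoro analogue sits at the weak end of this small set, by a modest margin. Among the measured compounds shown here, no measured pair tells whether more fluorine raises or lowers the number, so the expected step of a 1.4-fold lower number from compound 2 to compound 4 (0.13 log units; within the scatter) is set near no change beyond the scatter, with a wide range. For compound 4 in this assay the estimate is 22000 nM, expected to fall between 6000 nM and 70000 nM.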

Compound 4, half-maximal inhibitory concentration: 23400 nM
Estimate against measurement, compound 4: 1.1-fold (0.03 log units) below; measured number inside the range.
By their numbers in this assay, from the lowest: compounds 3 and 1 (each within the scatter of the next); then compounds 4 and 2 (each within the scatter of the next).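

In this assay, among the compounds shown here, the further fluoro groups of 3,4,5-trifluorophenyl in place of 3-fluorophenyl on this nitrogen give a 1.3-fold lower number from compound 2 to compound 4 (0.11 log units; within the scatter), so the first measured change of fluorine count at this position leaves the number unmoved within the scatter. The new compound also keeps the earlier split, with a 3.1-fold higher number from compound 3 to compound 4 (0.50 log units; beyond the scatter) and a 2.4-fold higher number from compound 1 to compound 4 (0.38 log units; beyond the scatter), so compound 2 and compound 4 form one group at the higher numbers and compound 1 and compound 3 another at the lower numbers, a division now seen across four aryl groups and claimed for no others. No supporting measurement is available to explain either the lack of a shift with more fluorine or the gap to the bromo and methyl analogues.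

The compounds shown leave open whether a 3,4,5-trichlorophenyl or 3,4,5-trimethylphenyl group on the same nitrogen would follow the fluoro pair or the bromo and methyl pair. They also leave open how an amine or a carboxylic acid on this ring, or a longer chain to the benzenesulfonamide amide, would move the number.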